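A few compounds are considered here, and "the series" means these few. Any claim that something is new, unique, unknown or untested is made for them only; others in the source may bear on it.

Compound 2, `COc1cc(CN(CC(C)C)C(CC(=O)O)c2ccc3c(c2)CCO3)ccc1OCCN1C(=O)CCC1=O`, gives 41 nM in an assay on CHO cells for displacement of a labelled ligand from C-X-C chemokine receptor type 3 (Homo sapiens), with a stated time of 60 min; a lower number here means a stronger inhibitor, a higher number a weaker inhibitor. That is the lowest of the two numbers at hand, but the nearest neighbour, compound 1, `Cc1cc(CN(CC2CCCCC2)C(CC(=O)O)c2ccc(Cl)cc2)ccc1OCCN1C(=O)CCC1=O`, gives 81 nM in this assay, and the two values lie within the scatter of each other, so neither compound can be called the stronger binder on this evidence. Going by the values given here, compound 1 and compound 2 differ in several places at once, so no single step between them is known.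

Compound 3, `COc1cc(CN(CC(C)C)C(CC(=O)O)c2ccc(Cl)cc2Cl)ccc1OCCN1C(=O)CCC1=O`, differs from compound 2 in one place: a group of 8 heavy atoms (6 carbon, 2 chlorine; one six-membered aromatic ring of carbon only) in place of a group of 9 heavy atoms (8 carbon, 1 oxygen; one five-membered non-aromatic ring with 1 hetero atom, one six-membered aromatic ring of carbon only), on a saturated chain carbon bound to an amine nitrogen and a saturated chain carbon. Among the compounds with values here, no step between measured compounds covers this exchange, so the expectation rests on the two values alone. Compound 1 also carries a chlorine-bearing phenyl ring on the same chain carbon and gives 81 nM, which speaks against a large loss from the exchange. The step from compound 2 to compound 3 is expected to be small, a 1.2-fold higher number from compound 2 to compound 3 (0.09 log units; within the scatter), and may not exceed the scatter. Compound 3 is therefore estimated at 50 nM, with a range from 15 nM to 170 nM.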

Compound 3, half-maximal inhibitory concentration: 110 nM
Compound 3: the middle estimate sits 2.2-fold (0.34 log units) below what was measured; low and high end bracket the measured number.
By their numbers in this assay, from the lowest: compounds 2, 1 and 3 (each within the scatter of the next, the first and the last beyond it).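

In this assay, going by these compounds alone, placing 2,4-dichlorophenyl on the saturated chain carbon bound to an amine nitrogen and a saturated chain carbon gives a 2.7-fold higher number from compound 2 to compound 3 (0.43 log units; beyond the scatter) and is the first exchange in this set confined to one place. It shows that the number responds to the group at this position, even though the two groups are close in size, with 8 heavy atoms entering for 9 and a six-membered aromatic ring of carbon only in both. The exchange also removes the five-membered non-aromatic ring and its hydrogen-bond acceptor and brings in two chlorine atoms, and no measurement here accounts for the change in the number.

As far as these compounds go, whether the ring oxygen, the five-membered ring or the chlorine atoms decide the outcome stays open, since these differences arrive together in a single exchange. An unsubstituted phenyl ring or a pyridine ring on the same carbon, with the rest of compound 2 kept, would separate them, whereas compound 1 differs in other places as well and cannot settle the question.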